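A few compounds are considered here, and "the series" means these few. Any claim that something is new, unique, unknown or untested is made for them only; others in the source may bear on it.

Measured in an ADME assay on BJ cells (Homo sapiens) for cytotoxicity, with a stated time of 72 h; a lower number here means that less compound is needed, a higher number that more compound is needed for the effect:
- Compound 1 `C=C[C@@](C)(/C=C/c1ccc(O)cc1)CCC(O)C(C)(C)O`: > 36600 nM
- Compound 2 `C=C[C@@](C)(/C=C/c1ccc(O)cc1)CC/C=C/C#N`: > 36600 nM
- Compound 3 `C=C[C@@](C)(/C=C/c1ccc(O)c(CO)c1)CCC=C(C)C`: > 36600 nM

Each of these three entries is a limit of the assay and not a number.

The starting point, compound 3, gives only the limit > 36600 nM. The same is true of the other two values, so the whole picture is the limit of > 36600 nM in this assay, at which 3 of the 3 values shown sit.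

The change to compound 4 `C=C[C@@](C)(/C=C/c1ccc(O)c(/C=C/C(=O)OCC)c1)CCC=C(C)C` takes place on an aromatic carbon, ortho to a hydroxy group. There, 2-(ethoxycarbonyl)ethenyl stands in place of hydroxymethyl (2-(ethoxycarbonyl)ethenyl in place of hydroxymethyl on an aromatic carbon).

Among the measured compounds shown here, only one measured step is available for comparison, and it offers little guidance. That step, a step that the two limits leave unreadable from compound 1 to compound 2, alters a saturated chain carbon rather than an aromatic carbon, and its size cannot be read. For the measured compounds named here, no measured step therefore tells how large a change on the aromatic carbon should be.

In this assay, the most likely outcome is no readable step, and compound 4 may well return another limit. Any measurable result could lie only on the lower side of that limit, so the range extends in that direction. The estimated step is an at least 1.2-fold lower number from compound 3 to compound 4 (0.08 log units; that floor lies within the scatter). For compound 4 the expected value is 30000 nM, with an estimated range from 9000 nM to 36600 nM.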

Compound 4, half-maximal effective concentration: > 36600 nM
Compound 4 was reported as a limit; the forecaster's own chance of this, stated with the estimate: 65%; at least 1.2-fold (0.08 log units) between middle value and limit.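

In this assay compound 4 gives > 36600 nM as a limit and not a number. Among the compounds shown here, compound 3 also stands at a limit, so no step between compound 3 and compound 4 can be read. The compounds shown leave open how far each lies from that limit and whether any of these changes matters in this assay at all.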